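Shifting the Chlorine on the Benzylsulfanyl Arm

The compounds below may be only part of what the source reports. "The series", "measured", "known", "first", "only" and "open" are said of these compounds alone.

Compound 1 `CC1=C(C(=O)Nc2ccc(F)cc2)C(c2ccc([N+](=O)[O-])cc2)N=C(SCc2ccccc2)N1`: 32.3%
Compound 2 `CC1=C(C(=O)Nc2ccc(Br)cc2)C(c2ccc(Cl)cc2Cl)N=C(SCc2ccccc2)N1`: 17.4%
Compound 3 `CC1=C(C(=O)Nc2ccc([N+](=O)[O-])cc2)C(c2ccc(Br)cc2)N=C(SCc2ccccc2Cl)N1`: 15.4%

In a functional assay on the whole organism (artery, strain albino) with Rattus norvegicus as the target, with a stated time of 240 min, at a dose of 10 mg/kg by the oral route (on this read-out lower numbers stand for less inhibition and higher numbers for more inhibition at the one dose given (going by the name of the read-out)), compound 3 stands at the bottom of the three numbers. Its nearest neighbour is compound 2, whose value lies within the usual scatter of that of compound 3, so the two cannot be ordered. Compound 1 lies further off, beyond the scatter, and is the highest of the three.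

Compound 4 `CC1=C(C(=O)Nc2ccc([N+](=O)[O-])cc2)C(c2ccc(Br)cc2)N=C(SCc2ccc(Cl)cc2)N1` differs from compound 3 in one place: 4-chlorophenyl in place of 2-chlorophenyl on a saturated chain carbon bound to a sulfur. Among the compounds with values here, no measured pair shows this change, so its effect has to be estimated. The expected step is a number 1.6 percentage points higher from compound 3 to compound 4 (within the scatter), a size that stays inside the scatter. Compound 4 is therefore expected to give about 17%, in a range from 5% to 30%.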

Compound 4, a percentage reported as inhibition, in the whole organism at one dose (the size of the read-out at that dose, not a potency): 29.7%
Compound 4: the middle estimate sits 12.7 percentage points below what was measured, within the range that was stated.
By their numbers in this assay, from the lowest: compounds 3 and 2 (each within the scatter of the next); then compounds 4 and 1 (each within the scatter of the next).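

In this assay, 4-chlorophenyl in place of 2-chlorophenyl on a saturated chain carbon bound to a sulfur gives a number 14.3 percentage points higher from compound 3 to compound 4 (beyond the scatter), with the same atoms joined differently. Within the data shown here, this is the first pair here that differs in one place, and it shows that where the chlorine sits on this arm can by itself move the read-out beyond the scatter. No measurement at hand accounts for the step.

The compounds shown leave open what 4-fluorophenyl or 4-methoxyphenyl would give on that carbon. They also leave open whether the step holds when other groups are carried elsewhere on the shared core.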